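Compound 3: a new piperidinyl side chain

This account rests on a few compounds, and the source may have more. Where it says the series, first, only, none or still open, it means among the compounds named here.

Measured in a functional assay on MCF7 cells (Homo sapiens) for antiproliferative activity; a higher number here means a weaker inhibitor, a lower number a stronger inhibitor:
- Compound 1 `CC(=O)Oc1ccc(C(=O)Nc2cc3ccc(OCCC4CCCCN4)c(C)c3oc2=O)cc1CC=C(C)C`: 710 nM
- Compound 2 `CC(C)=CCc1cc(C(=O)Nc2cc3ccc(OCCC4CCCCN4)c(C)c3oc2=O)ccc1O`: 710 nM

Set against compound 1, compound 2 stands level at 710 nM. Within the data shown here, the one measured step gives no change at the digits printed from compound 1 to compound 2 (within the scatter), with hydrogen in place of acetyl on an oxygen on an aromatic ring.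

The next compound to be tested is compound 3 `CC(C)=CCc1cc(C(=O)Nc2cc3ccc(OCC4CCCNC4)c(C)c3oc2=O)ccc1O`, and it differs from compound 2 elsewhere in the structure: piperidin-3-yl in place of (piperidin-2-yl)methyl on a saturated chain carbon bound to an oxygen on an aromatic ring. Piperidin-3-yl stands in place of (piperidin-2-yl)methyl on a saturated chain carbon bound to an oxygen on an aromatic ring. The same difference can be read as 2-(piperidin-2-yl)ethoxy to (piperidin-3-yl)methoxy.

The measured step concerns another place, so it bears on this change only weakly. Among the measured compounds shown here, no measured compound varies this side chain, and the data give no direction for the change. The expected result in this assay is therefore a 1.1-fold higher number from compound 2 to compound 3 (0.05 log units; within the scatter), with wide uncertainty on either side. For compound 3 the estimated value is 800 nM, with an expected range of 250 nM to 2500 nM.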

Compound 3, half-maximal inhibitory concentration: 790 nM
Compound 3: middle estimate off by 1.0-fold (0.01 log units), on the high side, within the range that was stated.
By their numbers in this assay, from the lowest: compounds 1, 2 and 3 (each within the scatter of the next).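

The side chain now has a measured reading: in this assay, piperidin-3-yl in place of (piperidin-2-yl)methyl gives a 1.1-fold higher number from compound 2 to compound 3 (0.05 log units; within the scatter). Read as 2-(piperidin-2-yl)ethoxy to (piperidin-3-yl)methoxy, this single change alters both the chain and the point where the piperidine ring is attached, yet the value stays within the scatter, so in this pair the place on a saturated chain carbon bound to an oxygen on an aromatic ring accepts both groups without a readable difference in this assay. Nothing in the available data explains this result, and no measurement of any property of these compounds bears on it.

Because the chain and the ring attachment change together in this one pair, the compounds shown do not separate the two, and they leave open whether each change alone would also stay within the scatter or whether the two would offset each other. As far as these compounds go, how a morpholine ring, an open dimethylamino group or a longer chain would read at this place also remains open.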